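A Trifluoromethyl Swap on the Shared Core

The source may report more compounds than this note shows. Statements on the series, on what has been measured and on what is new or still open speak of the compounds shown alone.

Within the data shown here, in a functional assay on K562 cells (Homo sapiens) for antiproliferative activity, with a stated time of 72 h (on this read-out higher numbers stand for weaker inhibition and lower numbers for stronger inhibition), compound 1 (`OC[C@H]1O[C@@H](n2cnc3c(NCc4ccccc4Cl)ncnc32)[C@H](O)[C@@H]1O`) gives 64000 nM and compound 2 (`OC[C@H]1O[C@@H](n2cnc3c(NCc4ccc(F)c(Cl)c4)ncnc32)[C@H](O)[C@@H]1O`) gives 5500 nM, the lower of the two numbers so far. Compound 3 (`OC[C@H]1O[C@@H](n2cnc3c(NCc4cccc(C(F)(F)F)c4)ncnc32)[C@H](O)[C@@H]1O`) keeps the shared core and differs from compound 2 in one place, on a saturated chain carbon bound to a nitrogen on an aromatic ring, where 3-(trifluoromethyl)phenyl takes the place of 3-chloro-4-fluorophenyl: 3-(trifluoromethyl)phenyl in place of 3-chloro-4-fluorophenyl on a saturated chain carbon bound to a nitrogen on an aromatic ring. Among the measured compounds shown here, only one measured step bears on this change, and it bears indirectly: a 12-fold lower number from compound 1 to compound 2 (1.07 log units; beyond the scatter). For the measured compounds named here, that large step shows that the group at this place can move the number, but no measured compound carries 3-(trifluoromethyl)phenyl. The estimated step is a 1.5-fold higher number from compound 2 to compound 3 (0.16 log units; within the scatter), so no change beyond the scatter is expected. The estimate for compound 3 is 8000 nM, with an expected range of 2500 nM to 30000 nM.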

Compound 3, half-maximal inhibitory concentration: > 166000 nM
Compound 3 ended at the assay's limit; the forecaster's own chance of this, stated with the estimate: 10%; middle value at least 20-fold (1.31 log units) from the limit.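

In this assay, compound 3 gives a limit and not a number: the limit of > 166000 nM in this assay, at which 1 of the 3 values shown sits. Putting 3-(trifluoromethyl)phenyl in place of 3-chloro-4-fluorophenyl gives an at least 30-fold higher number from compound 2 to compound 3 (1.47 log units; beyond the scatter), and putting it in place of 2-chlorophenyl gives an at least 2.5-fold higher number from compound 1 to compound 3 (0.41 log units; beyond the scatter). Among these compounds, the earlier step showed only that a change at this place can lower the number, whereas these steps show that a change here can also raise it, even though all three groups keep one six-membered aromatic ring of carbon only.

The three compounds do not separate the arrival of trifluoromethyl from the departure of chlorine and fluorine. On these data alone, how 3-chlorophenyl, 4-fluorophenyl or a phenyl ring bearing an amine or a carboxylic acid would read at this place remains open.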